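Chain extension and amine alkylation on the indole series

The source may report more compounds than this note shows. Statements on the series, on what has been measured and on what is new or still open speak of the compounds shown alone.

In an assay on urine for inhibition of Myeloperoxidase (Homo sapiens) (on this read-out higher numbers stand for weaker inhibition and lower numbers for stronger inhibition), compound 1 `NCc1c[nH]c2ccc(F)cc12` gives 900 nM, the highest of the three numbers recorded so far. Compound 2 `NCCCc1c[nH]c2ccc(F)cc12` gives 50 nM in this assay, and compound 3 `CNCCCc1c[nH]c2ccc(F)cc12` gives 200 nM. The steps are an 18-fold lower number from compound 1 to compound 2 (1.26 log units; beyond the scatter), a 4.5-fold lower number from compound 1 to compound 3 (0.65 log units; beyond the scatter) and a 4.0-fold higher number from compound 2 to compound 3 (0.60 log units; beyond the scatter).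

Compound 4 `CCNCCCc1c[nH]c2ccc(F)cc12` carries the change (2-(ethylamino)ethyl in place of amino on a saturated chain carbon bound to an aromatic carbon). Within the data shown here, two measured steps bear on it: the chain extension with a free amine, an 18-fold lower number from compound 1 to compound 2 (1.26 log units; beyond the scatter), and the same extension with a methyl on the amine, a 4.5-fold lower number from compound 1 to compound 3 (0.65 log units; beyond the scatter). The methyl alone costs a 4.0-fold higher number from compound 2 to compound 3 (0.60 log units; beyond the scatter), so the ethyl is taken to cost about as much or slightly more. From compound 1 a modest lowering is therefore expected in this assay, a 3.0-fold lower number from compound 1 to compound 4 (0.48 log units; beyond the scatter).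

For compound 4 the estimate in this assay is 300 nM, within 120 nM to 800 nM.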

Compound 4, half-maximal inhibitory concentration: 300 nM
Beside the measured number, compound 4's estimate shows no gap at the digits printed; the measured number falls inside the stated range.
By their numbers in this assay, from the lowest: compound 2; then compounds 3 and 4 (each within the scatter of the next); then compound 1.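

In this assay the 2-(ethylamino)ethyl change still improves on the amino starting point (a 3.0-fold lower number from compound 1 to compound 4 (0.48 log units; beyond the scatter)), but it falls short of the unsubstituted amine (a 6.0-fold higher number from compound 2 to compound 4 (0.78 log units; beyond the scatter)). Lengthening methyl to ethyl on the amine gives no difference that can be told apart (a 1.5-fold higher number from compound 3 to compound 4 (0.18 log units; within the scatter)), so among these compounds the size of the amine substituent does not separate compound 3 from compound 4, and both stay weaker than compound 2. No measurement on hand gives a reason for these steps.

Open, on these data alone, is whether a benzyl group or a second methyl on the amine nitrogen stays in the range of compounds 3 and 4, and whether a longer chain improves on compound 2. Also open, as far as these compounds go, is whether these steps carry over to a core without the fluorine.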